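Cytotoxicity at the Assay Limit: Compound 1 to Compound 4

The source may report more compounds than this note shows. Statements on the series, on what has been measured and on what is new or still open speak of the compounds shown alone.

Compound 1 `Cc1nc2cc(C(=O)NCc3ccc(F)cc3S(C)(=O)=O)nn2c(-c2cc(F)c3c(c2C)CCCO3)c1[C@H](OC(C)(C)C)C(=O)O` was tested in an ADME assay on MT2 cells (Homo sapiens) for cytotoxicity; a higher number here means that more compound is tolerated, a lower number that less compound is tolerated. In this assay compound 1 gives > 40000 nM, which is a limit of the assay and not a number. Two further compounds share its core. Compound 2 `Cc1nc2cc(C(=O)NCc3ccc(F)cc3N3CCCC3=O)nn2c(-c2cc(F)c3c(c2C)CCCO3)c1[C@H](OC(C)(C)C)C(=O)O` carries 2-oxopyrrolidin-1-yl in place of methylsulfonyl on an aromatic carbon, and in this assay compound 2 gives > 40000 nM, again a limit. Compound 3 `Cc1nc2cc(C(=O)NCC3CCCCC3)nn2c(-c2cc(F)c3c(c2C)CCCO3)c1[C@H](OC(C)(C)C)C(=O)O` carries cyclohexyl in place of 4-fluoro-2-(methylsulfonyl)phenyl on a saturated chain carbon bound to an amide-type nitrogen, and in this assay compound 3 gives > 40000 nM, also a limit. The step that the two limits leave unreadable from compound 1 to compound 2 and the step that the two limits leave unreadable from compound 1 to compound 3 thus cannot be sized. What the data offer is the limit of > 40000 nM in this assay, at which 3 of the 3 values shown sit, and compound 1 stands at it together with the other two.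

Compound 4 `Cc1nc2cc(C(=O)NCCC3CCOCC3)nn2c(-c2cc(F)c3c(c2C)CCCO3)c1[C@H](OC(C)(C)C)C(=O)O` differs from compound 1 as follows: (oxan-4-yl)methyl in place of 4-fluoro-2-(methylsulfonyl)phenyl on a saturated chain carbon bound to an amide-type nitrogen. The step from compound 1 to compound 3 is the one that bears on this change, as it too exchanges the same group at the same place, and its size was not readable. No direction can be read for the step in this assay beyond the scatter. The expected step is a step that the limit leaves unreadable from compound 1 to compound 4. Compound 4 is estimated at 60000 nM, within 30000 nM to 200000 nM.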

Compound 4, half-maximal cytotoxic concentration: > 40000 nM
Compound 4 was reported as a limit; the forecaster's own chance of this, stated with the estimate: 85%; the middle value lies beyond the limit too.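

In this assay compound 4 gives > 40000 nM, again a limit of the assay and not a number. The steps to compound 4 from compound 1 and from compound 3 therefore cannot be read, and all compounds stand together: the limit of > 40000 nM in this assay, at which 4 of the 4 values shown sit. Still open, going by these compounds, is the concentration at which any of the four compounds turns cytotoxic, and with it whether the exchanged groups differ at all.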